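Adding ethyl to the chain of compound 2

The source may hold more compounds than are shown below. What is called first, only, known or untested is meant among the compounds shown, and "the series" means these compounds.

- Compound 1 `CCCCOc1ccc(C2=C(c3ccc(O)cc3)[C@H]3O[C@@H]2C[C@@H]3S(=O)(=O)N(CC)c2ccccc2)cc1` gives 32800 nM
- Compound 2 `CCCCCCOc1ccc(C2=C(c3ccc(O)cc3)[C@H]3O[C@@H]2C[C@@H]3S(=O)(=O)N(CC)c2ccccc2)cc1` gives 42600 nM
- Compound 3 `CCCCCCOc1ccc(C2=C(c3ccc(O)cc3)[C@H]3C[C@H](S(=O)(=O)N(CC)c4ccccc4)[C@@H]2O3)cc1` gives > 100000 nM

In an ADME assay on MCF-10A cells (Homo sapiens) for cytotoxicity, read by MTT assay, with a stated time of 72 h (a lower number here means a stronger inhibitor, a higher number a weaker inhibitor), compound 2 gives 42600 nM, which lies within the scatter of compound 1 at 32800 nM. Compound 3 reads > 100000 nM, and this is a limit, not a number.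

The next compound to be tested is compound 4 `CCCCCCCCOc1ccc(C2=C(c3ccc(O)cc3)[C@H]3O[C@@H]2C[C@@H]3S(=O)(=O)N(CC)c2ccccc2)cc1`. It differs from compound 2 by ethyl in place of hydrogen on a saturated chain carbon, six bonds along the chain from an oxygen on an aromatic ring, with ethyl in place of hydrogen on a saturated chain carbon, six bonds along the chain from an oxygen on an aromatic ring.

For the measured compounds named here, one measured step bears on this change. The same swap, made four bonds along the chain from the oxygen, gave a 1.3-fold higher number from compound 1 to compound 2 (0.11 log units; within the scatter). One small step is thin evidence, but it gives no reason to expect a change beyond the scatter in this assay.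

The expected outcome is a 1.1-fold higher number from compound 2 to compound 4 (0.02 log units; within the scatter). For compound 4 the estimate is 45000 nM, with an expected range of 20000 nM to 100000 nM.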

Compound 4, half-maximal inhibitory concentration: 34600 nM
Estimate against measurement, compound 4: 1.3-fold (0.11 log units) above, and the stated range covers the measured number.
By their numbers in this assay, from the lowest: compounds 1, 4 and 2 (each within the scatter of the next). At a limit, above all of these: compound 3.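

In this assay, ethyl in place of hydrogen six bonds along the chain from an oxygen on an aromatic ring gives a 1.2-fold lower number from compound 2 to compound 4 (0.09 log units; within the scatter), so this outer position behaves like the one four bonds along, where the same swap also stayed within the scatter. The larger change, butyl in place of hydrogen at four bonds along the chain, gives a 1.1-fold higher number from compound 1 to compound 4 (0.02 log units; within the scatter), so the two ethyl additions taken together do not carry the reading beyond the scatter either. Nothing measured here explains why these chain lengths read alike.

Going by these compounds, whether the reading stays this level with a still longer chain remains open. So does what an amine or a carboxylic acid at the end of the chain would do.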